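From pyridin-3-yl to pyridin-4-yl with the 4-fluorophenyl group

The source may report more compounds than this note shows. Statements on the series, on what has been measured and on what is new or still open speak of the compounds shown alone.

In a functional assay on MCF7 cells (Homo sapiens) for inhibition, with a stated time of 96 h (on this read-out lower numbers stand for stronger inhibition and higher numbers for weaker inhibition), compound 1 (`COc1cc(C(=O)c2cn(-c3ccc(F)cc3)cc2-c2ccco2)cc(OC)c1OC`) gives 17 nM. Compound 2 (`COc1cc(C(=O)c2cn(-c3cccc(C)c3)cc2-c2ccncc2)cc(OC)c1OC`) gives 65 nM, and compound 3 (`COc1cc(C(=O)c2cn(-c3ccc(F)cc3)cc2-c2cccnc2)cc(OC)c1OC`) gives 39 nM. Compound 3 therefore lies within the scatter of compound 2, while its number is higher than that of compound 1 by more than the scatter.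

The next case is compound 4 (`COc1cc(C(=O)c2cn(-c3ccc(F)cc3)cc2-c2ccncc2)cc(OC)c1OC`), which differs from compound 3 as follows: pyridin-4-yl in place of pyridin-3-yl on an aromatic carbon. In short, pyridin-4-yl stands in place of pyridin-3-yl on an aromatic carbon.

Among the compounds with values here, no measured step covers this exact exchange. The closest is at the same place, a 2.3-fold higher number from compound 1 to compound 3 (0.36 log units; beyond the scatter), a modest step for pyridin-3-yl in place of furan-2-yl. That exchange replaces one ring type with another, whereas here the entering and leaving groups match in everything counted. Compound 2 also carries pyridin-4-yl but lacks the 4-fluorophenyl group, so its 65 nM is only a rough guide.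

No step beyond the scatter is therefore expected in this assay, and the small upward lean follows compound 2 at 65 nM. The expected change is a 1.2-fold higher number from compound 3 to compound 4 (0.06 log units; within the scatter). For compound 4 the estimate is 45 nM, with an expected range of 20 nM to 100 nM.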

Compound 4, half-maximal inhibitory concentration: 9 nM
Beside the measured number, compound 4's estimate is 5.0-fold (0.70 log units) above it; the measured number lies below the stated range.
By their numbers in this assay, from the lowest: compounds 4 and 1 (each within the scatter of the next); then compounds 3 and 2 (each within the scatter of the next).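

In this assay, the exchange of pyridin-3-yl for pyridin-4-yl gives a 4.3-fold lower number from compound 3 to compound 4 (0.64 log units; beyond the scatter) even though the two groups match in everything counted, so at this place on the five-membered aromatic ring the point of attachment of the pyridine matters and not just its counted make-up. With pyridin-4-yl held, the group on the aromatic nitrogen also matters: 4-fluorophenyl in place of 3-methylphenyl gives a 7.2-fold lower number from compound 2 to compound 4 (0.86 log units; beyond the scatter) in the same assay. With 4-fluorophenyl held, pyridin-4-yl in place of furan-2-yl gives a 1.9-fold lower number from compound 1 to compound 4 (0.28 log units; within the scatter) and so does not separate the two groups, whereas pyridin-3-yl in place of furan-2-yl gave a 2.3-fold higher number from compound 1 to compound 3 (0.36 log units; beyond the scatter) and did.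

On these data alone, whether pyridin-2-yl or a plain phenyl group at this place would read like pyridin-4-yl or like pyridin-3-yl remains open, as does whether the exchange of 3-methylphenyl for 4-fluorophenyl gives a similar step with pyridin-3-yl or furan-2-yl at this place. Nothing on hand speaks to the reason for the difference between pyridin-3-yl and pyridin-4-yl.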